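Phenyl in Place of Naphthalenyl: Expected Cytotoxicity

A few compounds are considered here, and "the series" means these few. Any claim that something is new, unique, unknown or untested is made for them only; others in the source may bear on it.

Measured compounds:
compound 1 `O=C(NC1CCC(CN2CCN(c3cc(=O)c4cc(C(F)(F)F)cc([N+](=O)[O-])c4s3)CC2)CC1)c1ccccc1`: 44.3 ug/mL
compound 2 `O=c1cc(N2CCN(CC3CCC(OS(=O)(=O)c4ccc5ccccc5c4)CC3)CC2)sc2c([N+](=O)[O-])cc(C(F)(F)F)cc12`: > 64 ug/mL

In an ADME assay on Vero cells (Chlorocebus sabaeus) for cytotoxicity, read by MTT assay, with a stated time of 48 h (on this read-out lower numbers stand for stronger inhibition and higher numbers for weaker inhibition), compound 1 gives 44.3 ug/mL. Compound 2 in this assay gives only a limit, > 64 ug/mL, so no exact number is known for it; this is the limit of > 64 ug/mL in this assay, at which 1 of the 2 values shown sits. Compound 3 `O=c1cc(N2CCN(CC3CCC(OS(=O)(=O)c4ccccc4)CC3)CC2)sc2c([N+](=O)[O-])cc(C(F)(F)F)cc12` differs from compound 2 by phenyl in place of naphthalen-2-yl on a sulfonyl sulfur. For the measured compounds named here, no measured pair here shows what such a change does, so the step from compound 2 to compound 3 is expected to stay within the scatter, an at least 1.0-fold lower number from compound 2 to compound 3 (0.02 log units; that floor lies within the scatter). Compound 3 is thus expected to give about 60 ug/mL, between 30 ug/mL and 120 ug/mL, with a fair chance that this assay again reports only a limit.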

Compound 3, half-maximal inhibitory concentration: > 64 ug/mL
Compound 3: a limit, no number (the forecaster's own chance of this, stated with the estimate: 50%); at least 1.0-fold (0.02 log units) between middle value and limit.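

In this assay compound 3 gives only a limit, so the step from naphthalen-2-yl to phenyl on the sulfonyl sulfur cannot be read. Even so, with one aromatic ring in place of two, the read-out stays at a limit, and the values now gather there: the limit of > 64 ug/mL in this assay, at which 2 of the 3 values shown sit. The (phenylsulfonyl)oxy group in place of benzamido on a saturated ring carbon gives an at least 1.4-fold higher number from compound 1 to compound 3 (0.15 log units; that floor lies within the scatter).

As far as these compounds go, how far compound 2 and compound 3 lie past their limits stays open. So does whether an amine or a carboxylic acid on the phenyl ring would give a readable number.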